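The source may hold more compounds than are shown below. What is called first, only, known or untested is meant among the compounds shown, and "the series" means these compounds.

In a functional assay on A549 cells (Homo sapiens) for inhibition, read by sulforhodamine B assay, with a stated time of 48 h, tested at 50 uM (a lower number here means less inhibition of growth, a higher number more inhibition of growth at the concentration tested), compound 2 (`COc1ccc([C@@H]2CC(=O)c3cc(CC=C(C)C)c(OC)cc3O2)cc1`) gives 45%. Compound 1 (`COc1ccc([C@@H]2C/C(=N/OCc3cn(-c4ccc(O)cc4)nn3)c3cc(CC=C(C)C)c(OC)cc3O2)cc1`), a relative with the shared core, gives 52%. These two numbers lie within the scatter of each other, so neither can be ranked above the other. Compound 3 (`CCCCOc1ccc([C@@H]2CC(=O)c3cc(CC=C(C)C)c(OC)cc3O2)cc1`) has not yet been measured. It differs from compound 2 in one place: propyl in place of hydrogen on a saturated chain carbon bound to an oxygen on an aromatic ring. Put simply, a methoxy becomes a butoxy, with propyl in place of hydrogen on a saturated chain carbon bound to an oxygen on an aromatic ring. Within the data shown here, no measured pair shows what such a change does in this assay, so the expectation rests on little. The likeliest outcome is no shift beyond the scatter, in no firm direction. The estimated step of a number 2 percentage points higher from compound 2 to compound 3 (within the scatter) is correspondingly small. For compound 3 the expected value is 47%, with an estimated range of 32% to 63%.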

Compound 3, percent growth inhibition at one concentration: 37%
Beside the measured number, compound 3's estimate is 10 percentage points above it; low and high end bracket the measured number.
By their numbers in this assay, from the lowest: compounds 3, 2 and 1 (each within the scatter of the next, the first and the last beyond it).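

In this assay, among these compounds, going from methoxy to butoxy gives a number 8 percentage points lower from compound 2 to compound 3 (within the scatter) and so offers the first direct look at this position, on a saturated chain carbon bound to an oxygen on an aromatic ring. This single pair gives no sign that adding propyl here shifts growth inhibition by more than repeat measurements could, so compound 2 and compound 3 cannot be told apart. Nothing available explains this result or ties it to any property of the chain.

Still open, on these data alone, is what a shorter ethoxy, a branched isopropoxy, a longer hexyloxy or a chain ending in an amine would do at this position. With only methoxy and butoxy to compare, no trend with chain length can be drawn, in either direction.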